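Estimating a benzyl swap on the amide of compound 3

The source may report more compounds than this note shows. Statements on the series, on what has been measured and on what is new or still open speak of the compounds shown alone.

In a functional assay on SK-BR-3 cells (Homo sapiens) for cytotoxicity, read by MTT assay, with a stated time of 72 h (on this read-out lower numbers stand for stronger inhibition and higher numbers for weaker inhibition), the measured compounds read as follows:
compound 1 (`Nc1ccc(Nc2c(C(=O)NCc3ccc(F)cc3)nc(Br)c3cccnc23)cc1`) gives 4000 nM
compound 2 (`CN(C)CCCNc1c(C(=O)NCc2ccc(F)cc2)nc(Br)c2cccnc12`) gives 1000 nM
compound 3 (`COc1cccc(CNC(=O)c2nc(Br)c3cccnc3c2N[C@H]2CC[C@H](N)CC2)c1`) gives 6000 nM

In this assay compound 3 (6000 nM) lies within the scatter of compound 1 (4000 nM). Compound 2 (1000 nM) shows a lower number than compound 3, and that gap is beyond the scatter.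

The next structure is compound 4 (`N[C@H]1CC[C@H](Nc2c(C(=O)NCc3ccc(Cl)cc3)nc(Br)c3cccnc23)CC1`). Its difference from compound 3 is 4-chlorophenyl in place of 3-methoxyphenyl on a saturated chain carbon bound to an amide-type nitrogen and in words it is 4-chlorophenyl in place of 3-methoxyphenyl on a saturated chain carbon bound to an amide-type nitrogen.

Among the compounds with values here, only one measured step exists, a 4.0-fold lower number from compound 1 to compound 2 (0.60 log units; beyond the scatter) and it is modest. That step has 3-(dimethylamino)propyl in place of 4-aminophenyl on a nitrogen on an aromatic ring, so it leaves the amide side untouched and says nothing direct about this swap. Within the data shown here, no measured pair changes the group that changes here, so the data give no direction for it.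

The expected change is therefore small, and the estimate is a 1.5-fold lower number from compound 3 to compound 4 (0.18 log units; within the scatter) and so nothing beyond the scatter. The estimate for compound 4 is 4000 nM (expected range 1500 nM to 10000 nM).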

Compound 4, half-maximal inhibitory concentration: 2000 nM
For compound 4 the middle estimate is 2.0-fold (0.30 log units) above the measured one; low and high end bracket the measured number.
By their numbers in this assay, from the lowest: compounds 2, 4, 1 and 3 (each within the scatter of the next, the first and the last beyond it).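

In this assay, the exchange of 3-methoxybenzyl for 4-chlorobenzyl gives a 3.0-fold lower number from compound 3 to compound 4 (0.48 log units; beyond the scatter), with the rest of the molecule unchanged. Within the data shown here, this is the first sign that the group on the saturated chain carbon bound to an amide-type nitrogen can move the read-out beyond the scatter, since the only earlier step, a 4.0-fold lower number from compound 1 to compound 2 (0.60 log units; beyond the scatter), concerned a different place on the shared core; both steps are modest. The change takes out a 3-methoxyphenyl, with its hydrogen-bond acceptor, and puts in a 4-chlorophenyl, which has none, but nothing available explains why the number falls.

The compounds shown leave open which part of this change carries the step, as the substituent and its place on the phenyl ring change together, and a 3-chlorobenzyl or a 4-methoxybenzyl on the same amide would be needed to separate the two. An unsubstituted benzyl in this place would also show whether the 4-chlorophenyl lowers the number or the 3-methoxyphenyl raises it.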